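Amide to acid on the carbonyl of compound 1

A few compounds are considered here, and "the series" means these few. Any claim that something is new, unique, unknown or untested is made for them only; others in the source may bear on it.

Within the data shown here, compound 1 `C=CC1=C(C(=O)NC2CCCCC2)C(c2ccc(OC)c(OC)c2)OC1` is the only member of this set with a numerical read-out: in a functional assay on SW480 cells (Homo sapiens) for cytotoxicity, read by MTT assay, with a stated time of 24 h (a lower number here means a stronger inhibitor, a higher number a weaker inhibitor), compound 1 gives 19100 nM. Compound 2 `C=CC1=C(C(=O)NC(C)(C)C)C(c2ccc(F)cc2)OC1` reaches only the limit of the assay, > 100000 nM. Compound 3 `C=CC1=C(C(=O)NC2CCCCC2)C(c2ccc(OC)cc2)OC1` likewise reaches only the limit, > 100000 nM. Among the measured compounds shown here, the set is therefore dominated by the limit of > 100000 nM in this assay, at which 2 of the 3 values shown sit, and compound 1 stands as the one compound below it.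

One measured step is defined within the set: an at least 5.2-fold higher number from compound 1 to compound 3 (0.71 log units; beyond the scatter). It concerns the aromatic methoxy, not the carbonyl substituent.

Compound 4 `C=CC1=C(C(=O)O)C(c2ccc(OC)c(OC)c2)OC1` is not yet measured. It differs from compound 1 in one place, (hydroxy in place of cyclohexylamino on a carbonyl carbon), that is, hydroxy in place of cyclohexylamino on a carbonyl carbon. For the measured compounds named here, no measured step touches this position, so the direction of the change cannot be read from a matched pair. The only orientation available is that two of three values sit at the limit of > 100000 nM in this assay, at which 2 of the 3 values shown sit, which makes a number at or near the limit the likelier outcome for any change from compound 1.

Compound 4 is therefore expected to give about 60000 nM, within 15000 nM to 150000 nM. The step from compound 1 to compound 4 that this expectation implies is a 3.1-fold higher number from compound 1 to compound 4 (0.50 log units; beyond the scatter).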

Compound 4, half-maximal inhibitory concentration: > 100000 nM
Compound 4: only a limit was reported (the forecaster's own chance of this, stated with the estimate: 55%); middle value at least 1.6-fold (0.22 log units) from the limit.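

Carbonyl position, first reading: hydroxy in place of cyclohexylamino on the carbonyl carbon gives an at least 5.2-fold higher number from compound 1 to compound 4 (0.71 log units; beyond the scatter), so this position, untouched by the earlier step, also counts in this assay. From the compounds shown here alone, compound 4 gives > 100000 nM, which is a limit of the assay, so the step has a lower bound only and its full size stays unknown. Among these compounds, compound 3 and compound 4 each differ from compound 1 in one place, at the aromatic methoxy and at the carbonyl respectively named above, and each change ends at the same ceiling, leaving compound 1 as the only compound with a number: the limit of > 100000 nM in this assay, at which 3 of the 4 values shown sit.

The compounds shown leave open whether the amide nitrogen as such or the cyclohexyl ring is what matters here; a primary amide, a methyl ester or a cyclopentylamino group on the same carbonyl carbon would separate the two. Equally open, going by these compounds, is whether any group at this position can give a stronger inhibitor than compound 1, which gives 19100 nM.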